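Triazole aryl variation on the shared spiro-oxindole core

A few compounds are considered here, and "the series" means these few. Any claim that something is new, unique, unknown or untested is made for them only; others in the source may bear on it.

Measured so far in a functional assay on HepG2 cells (Homo sapiens) for antiproliferative activity, read by MTT assay, with a stated time of 48 h; a higher number here means a weaker inhibitor, a lower number a stronger inhibitor:
compound 1 `Cc1ccccc1-n1nncc1CN1C(=O)C2(C(C#N)=C(N)Oc3c(N)cc4nc5ccccc5nc4c32)c2ccccc21` — > 50000 nM
compound 2 `N#CC1=C(N)Oc2c(N)cc3nc4ccccc4nc3c2C12C(=O)N(Cc1cnnn1-c1cccc(C(F)(F)F)c1)c1ccccc12` — 15800 nM
compound 3 `Cc1cc(C)cc(-n2nncc2CN2C(=O)C3(C(C#N)=C(N)Oc4c(N)cc5nc6ccccc6nc5c43)c3ccccc32)c1` — > 50000 nM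

The three compounds share one core and differ only in the aryl group on the aromatic nitrogen of the triazole ring. Among the compounds with values here, compound 2, with 3-(trifluoromethyl)phenyl, is the only one that gives a number, 15800 nM. Compound 1 reaches only the limit of this assay, > 50000 nM. Compound 3 likewise gives only the limit, > 50000 nM. Compound 3 thus stands where (the limit of > 50000 nM in this assay, at which 2 of the 3 values shown sit), and the comparison with compound 2 reads as an at least 3.1-fold higher number from compound 2 to compound 3 (0.50 log units; beyond the scatter). The parallel step an at least 3.1-fold lower number from compound 1 to compound 2 (0.50 log units; beyond the scatter) points the same way for the trifluoromethyl-bearing aryl, whereas a step that the two limits leave unreadable from compound 1 to compound 3.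

Compound 4 `N#CC1=C(N)Oc2c(N)cc3nc4ccccc4nc3c2C12C(=O)N(Cc1cnnn1-c1ccc(F)c(Cl)c1)c1ccccc12` carries 3-chloro-4-fluorophenyl in place of 3,5-dimethylphenyl on an aromatic nitrogen. Within the data shown here, the step that bears on it is the one from compound 3 to compound 2, where a methyl-substituted phenyl was exchanged for a halogenated one and the number fell beyond the scatter. Compound 4 is therefore expected to move off the limit in the direction of compound 2, with the step from the limit estimated as an at least 2.0-fold lower number from compound 3 to compound 4 (0.30 log units; that floor lies within the scatter). The value of compound 4 in this assay is estimated at 25000 nM, within 8000 nM to 50000 nM.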

Compound 4, half-maximal inhibitory concentration: > 50000 nM
Compound 4: a limit, no number (the forecaster's own chance of this, stated with the estimate: 40%); middle value at least 2.0-fold (0.30 log units) from the limit.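

In this assay compound 4 gives > 50000 nM, which is a limit of the assay and not a number. A halogenated aryl group on this triazole nitrogen is therefore not enough on its own to give a reading, as 3-chloro-4-fluorophenyl in place of 3-(trifluoromethyl)phenyl produces an at least 3.1-fold higher number from compound 2 to compound 4 (0.50 log units; beyond the scatter), while the steps among compounds 1, 3 and 4 cannot be read, both ends of each being limits. Compound 2 remains the only compound of the four with a measured number, and the methyl-bearing and chloro-fluoro aryl groups now share a single reading: the limit of > 50000 nM in this assay, at which 3 of the 4 values shown sit.

The compounds shown leave open whether the response of compound 2 is tied to the trifluoromethyl group itself, and whether a methoxy group, an amine or a carboxylic acid on the phenyl ring, or a longer alkyl chain in place of the aryl group, would also give a number. They also leave open how compounds 1, 3 and 4 rank among themselves, with all three resting on the same limit.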